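Aryl swap on the triazole of a weakly active spirooxindole

A few compounds are considered here, and "the series" means these few. Any claim that something is new, unique, unknown or untested is made for them only; others in the source may bear on it.

Compound 3 `Cc1ccc(C)c(-n2nncc2CN2C(=O)C3(C(C#N)=C(N)Oc4c(N)cc5nc6ccccc6nc5c43)c3ccccc32)c1` is one of three analogues that share a common core and differ only in the aryl group carried on the triazole nitrogen. In a functional assay on HCT-116 cells (Homo sapiens) for antiproliferative activity, read by MTT assay, with a stated time of 48 h (on this read-out lower numbers stand for stronger inhibition and higher numbers for weaker inhibition), compound 3 reaches only a limit, > 50000 nM. Compound 2 `COc1ccc(-n2nncc2CN2C(=O)C3(C(C#N)=C(N)Oc4c(N)cc5nc6ccccc6nc5c43)c3ccccc32)cc1` likewise gives only a limit in this assay, > 50000 nM. Among the compounds with values here, compound 1 `N#CC1=C(N)Oc2c(N)cc3nc4ccccc4nc3c2C12C(=O)N(Cc1cnnn1-c1ccccc1Br)c1ccccc12`, the only member with a measurable number, gives 12400 nM in this assay. The steps from that compound are an at least 4.0-fold higher number from compound 1 to compound 2 (0.60 log units; beyond the scatter) and an at least 4.0-fold higher number from compound 1 to compound 3 (0.60 log units; beyond the scatter), while the comparison of the two limits is a step that the two limits leave unreadable from compound 2 to compound 3; these limits are fixed by the limit of > 50000 nM in this assay, at which 2 of the 3 values shown sit. So compound 3 stands at the weak end of what the numbers can show.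

Compound 4 `N#CC1=C(N)Oc2c(N)cc3nc4ccccc4nc3c2C12C(=O)N(Cc1cnnn1-c1cc(Cl)ccc1Cl)c1ccccc12` arises from compound 3 by 2,5-dichlorophenyl in place of 2,5-dimethylphenyl on an aromatic nitrogen. The measured steps that bear on this change all move away from compound 1 toward the limit, and the two aryl groups already tested there, one of them also substituted at the same two positions, both left the number beyond reach. Compound 4 is therefore expected to remain weak in this assay, with an estimated step of an at least 1.2-fold lower number from compound 3 to compound 4 (0.09 log units; that floor lies within the scatter) that cannot be read beyond the scatter. The estimate for compound 4 is 40000 nM, within 12000 nM to 100000 nM.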

Compound 4, half-maximal inhibitory concentration: > 50000 nM
Compound 4: no number, only a limit; the forecaster's own chance of this, stated with the estimate: 55%; middle value at least 1.2-fold (0.09 log units) away from the limit.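

Replacing 2,5-dimethylphenyl with 2,5-dichlorophenyl on the triazole nitrogen does not lift the compound out of the limit in this assay: compound 4 gives only a limit, which shows that carrying halogen on this aryl group is not enough by itself to give a measurable number. Measured against the 2-bromophenyl group, the change gives an at least 4.0-fold higher number from compound 1 to compound 4 (0.60 log units; beyond the scatter), so compound 1, itself a halogen-bearing member, remains the only one of the four aryl variants with a number. The steps among compound 2, compound 3 and compound 4 cannot be read, because each of them joins two limits: the limit of > 50000 nM in this assay, at which 3 of the 4 values shown sit.

On these data alone, how far the true values of compound 2, compound 3 and compound 4 lie beyond that limit remains unknown, and so does any order among them. The compounds shown also leave open whether the number of compound 1 depends on bromine itself or on the aryl ring carrying a single substituent, a question that plain phenyl or 2-chlorophenyl on the triazole nitrogen would bear on, as would an amine or a carboxylic acid on that ring.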